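Swapping hydroxy for (dimethylamino)methyl on compound 2

A few compounds are considered here, and "the series" means these few. Any claim that something is new, unique, unknown or untested is made for them only; others in the source may bear on it.

In a functional assay on the whole organism (stomach) with Rattus norvegicus as the target (a lower number here means that less compound is needed, a higher number that more compound is needed for the effect), compound 2 `OCC/N=C(\S)C1(c2ccccn2)CCCS1` gives > 30 mg/kg as a limit of the assay, not a number. Compound 3 `C=CCNC(=S)C1(c2ccccn2)CCCS1` gives > 30 mg/kg as a limit too. Compound 1 `S=C(NCc1ccccc1)C1(c2ccccn2)CCCS1` gives <= 30 mg/kg as a limit as well. Compound 4 `CN(C)CCC/N=C(\S)C1(c2ccccn2)CCCS1`, not yet measured, carries (dimethylamino)methyl in place of hydroxy on a saturated chain carbon, two bonds along the chain from a double-bonded nitrogen on the shared core. Going by the values given here, the one measured step of a number no lower from compound 1 to compound 3 (the limit leaves the size open) concerns another group and its size cannot be read, so it guides neither size nor direction here. The estimated step that the limit leaves unreadable from compound 2 to compound 4 therefore stays within the scatter, with no direction expected. For compound 4 the expected dose is 40 mg/kg within a range of 15 mg/kg to 100 mg/kg in this measurement. A limit is the likeliest report.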

Compound 4, dose for half-maximal effect: > 30 mg/kg
Compound 4 ended at the assay's limit; the forecaster's own chance of this, stated with the estimate: 70%; the middle value does not contradict the limit.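

Compound 2 and compound 4 each give only a limit, not a number, and the step between them cannot be read. The compounds shown leave open whether swapping hydroxy for (dimethylamino)methyl changes the dose needed at all.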